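This account rests on a few compounds, and the source may have more. Where it says the series, first, only, none or still open, it means among the compounds named here.

Compound 1 `C#CCN(Cc1ccc2nc(C)nc(O)c2c1)c1ccc([N+](=O)[O-])cc1` gives 4800 nM in a functional assay on GC3/MTK- cells (Homo sapiens) for inhibition (a higher number here means a weaker inhibitor, a lower number a stronger inhibitor), and compound 2 `C#CCN(Cc1ccc2nc(C)nc(O)c2c1)c1ccc(S(=O)(=O)c2ccccc2)c(C(F)(F)F)c1` gives 7500 nM so the two lie within the usual scatter of each other and cannot be ranked. Going by the values given here, compound 1 therefore stands level with the only other measured compound. Compound 3 `C#CCN(Cc1ccc2nc(C)nc(O)c2c1)c1ccc(S(=O)(=O)N2CCN(C)CC2)cc1` keeps the core of compound 1 but carries (4-methylpiperazin-1-yl)sulfonyl in place of nitro on an aromatic carbon and this is a much larger group. Among the compounds with values here, no measured pair differing in one place shows what such a change does. Within the data shown here, the one hint is compound 2, which also holds a sulfonyl group and gives 7500 nM without separating from compound 1. The expected step of a 1.7-fold higher number from compound 1 to compound 3 (0.22 log units; within the scatter) is small, leaning towards a weaker inhibitor but staying within the scatter. For compound 3 the estimated value is 8000 nM with 2500 nM to 25000 nM as the expected range.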

Compound 3, half-maximal inhibitory concentration: > 10000 nM
Compound 3 ended at the assay's limit (the forecaster's own chance of this, stated with the estimate: 15%); at least 1.2-fold (0.09 log units) between middle value and limit.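

In this assay, putting (4-methylpiperazin-1-yl)sulfonyl in place of nitro on this aromatic carbon gives an at least 2.0-fold higher number from compound 1 to compound 3 (0.31 log units; beyond the scatter), so a change at this one place can now be seen to weaken inhibition, which the first two compounds could not show. For compound 3 the value > 10000 nM is a limit of the assay, not a number. Going by these compounds, the step is therefore only a minimum, and its true size stays unknown because of that limit: the limit of > 10000 nM in this assay, at which 1 of the 3 values shown sits.

The compounds shown leave open which part of the new group goes with the weaker inhibition, the sulfonyl or the ring that follows it. They also leave open how a nitrile, a carboxylic acid or a plain amine would read on this same aromatic carbon.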